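Opening the Ring: Cyclopentyl to Pentan-3-yl

This account rests on a few compounds, and the source may have more. Where it says the series, first, only, none or still open, it means among the compounds named here.

Measured compounds and their values:
Compound 1, `O=C(/C=C/c1ccc(O)cc1)c1c(O)cccc1OCC1CCCC1`: 3410 nM
Compound 2, `CC(C)(C)CCOc1cccc(O)c1C(=O)CCc1ccc(O)cc1`: > 30000 nM
Compound 3, `CC(C)(C)CCOc1cccc(O)c1C(=O)/C=C/c1ccc(S(N)(=O)=O)cc1`: 2930 nM

In a functional assay on HCT-15 cells (Homo sapiens) for antiproliferative activity, read by sulforhodamine B assay (a higher number here means a weaker inhibitor of growth, a lower number a stronger inhibitor of growth), compound 1 gives 3410 nM, the higher of the two numbers shown. Compound 3 gives 2930 nM, and the gap between these two lies within the usual scatter, so neither can be called the stronger. For compound 2 the result is a limit of the assay and not a number: the limit of > 30000 nM in this assay, at which 1 of the 3 values shown sits.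

Compound 4, `CCC(CC)COc1cccc(O)c1C(=O)/C=C/c1ccc(O)cc1`, has not yet been measured. It differs from compound 1 in one place: pentan-3-yl in place of cyclopentyl on a saturated chain carbon bound to an oxygen on an aromatic ring. The two groups hold the same count of carbon atoms; only the ring is opened. Among the compounds with values here, no measured pair here shows what such a change does, so the expected step of a 1.0-fold lower number from compound 1 to compound 4 (0.00 log units; within the scatter) is small, with no movement beyond the scatter. Compound 4 is therefore estimated at 3400 nM, with a range from 1500 nM to 8000 nM.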

Compound 4, concentration for 50% growth inhibition: 3420 nM
Compound 4: middle estimate off by 1.0-fold (0.00 log units), on the low side, and the stated range covers the measured number.
By their numbers in this assay, from the lowest: compounds 3, 1 and 4 (each within the scatter of the next). At a limit, above all of these: compound 2.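

Replacing the cyclopentyl ring with the open pentan-3-yl group, which holds the same count of carbon atoms, gives a 1.0-fold higher number from compound 1 to compound 4 (0.00 log units; within the scatter) in this assay. Within the data shown here, this pair is the first here to test this place, a saturated chain carbon bound to an oxygen on an aromatic ring, and it shows that the closed ring is not required for this level of growth inhibition on the core of compound 1. Nothing measured here explains why the two groups read alike.

As far as these compounds go, it remains open whether this place accepts other kinds of group, such as a longer chain, cyclohexyl, an amine or a carboxylic acid. This single pair also cannot show whether the same ring opening would read alike on a different core.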